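From Compound 1 to Compound 3 in MCF7 Cells

The compounds below may be only part of what the source reports. "The series", "measured", "known", "first", "only" and "open" are said of these compounds alone.

Compound 1 `COc1cc(Cl)cc(-c2nn(-c3cccc(NC(=O)Nc4ccc(Cl)c(C(F)(F)F)c4)c3)cc2-c2ccncc2)c1` and compound 2 `COc1cc(Cl)cc(-c2nn(-c3cccc(NC(=O)Nc4cc(C(F)(F)F)cc(C(F)(F)F)c4)c3)cc2-c2ccncc2)c1` share the same core and differ only in the substituted ring at the far end of the urea. In a functional assay on MCF7 cells (Homo sapiens) for inhibition, read by sulforhodamine B assay, with a stated time of 48 h, tested at 1 uM (a higher number here means a weaker effect of the compound at the concentration tested, a lower number a stronger effect), compound 1 gives 50%, and compound 2 gives 21%. Of these two numbers, that of compound 1 is the highest, and its nearest neighbour, compound 2, lies below it by a gap that is beyond the scatter, so compound 1 shows the weaker effect of the two.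

Compound 3 `COc1cc(Cl)cc(-c2nn(-c3cccc(NC(=O)c4cccc(C(F)(F)F)c4)c3)cc2-c2ccncc2)c1` has not been measured. It differs from compound 1 in one place: 3-(trifluoromethyl)phenyl in place of (4-chloro-3-(trifluoromethyl)phenyl)amino on a carbonyl carbon. The change is on a carbonyl carbon whose other neighbour is an amide-type nitrogen.

For the measured compounds named here, no step between measured compounds is available, so the expectation rests on compound 1 alone. A step of a number 5 percentage points higher from compound 1 to compound 3 (within the scatter) is expected, small and upward if anything, meaning a slightly weaker effect or none beyond the scatter. For compound 3 the estimate in this assay is 55%, with a range from 30% to 85%.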

Compound 3, a percentage reported as activity, at one concentration (the size of the read-out at that concentration, not a potency): 57%
Compound 3: the middle estimate sits 2 percentage points below what was measured; low and high end bracket the measured number.
By their numbers in this assay, from the lowest: compound 2; then compounds 1 and 3 (each within the scatter of the next).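

In this assay, placing 3-(trifluoromethyl)phenyl in place of (4-chloro-3-(trifluoromethyl)phenyl)amino on the carbonyl carbon gives a number 7 percentage points higher from compound 1 to compound 3 (within the scatter), so the read-out at this one concentration does not tell the two compounds apart. Compounds 1 and 2 both keep the urea and differ only in the substituted ring at its far end, whereas compound 3 shows that this carbonyl carbon can lose the amino nitrogen, with its hydrogen-bond donor, and the chlorine in a single change without a shift beyond the scatter; the two losses are not separated here. Nothing measured here accounts for this result.

As far as these compounds go, what stays open is whether the ring of compound 2, with its two trifluoromethyl groups, would keep its stronger effect when attached directly to the carbonyl carbon as in compound 3. Also open is how this carbonyl carbon would respond to a benzyl group or a simple alkyl amine, and how any of these compounds would compare at other concentrations.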